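The compounds below may be only part of what the source reports. "The series", "measured", "known", "first", "only" and "open" are said of these compounds alone.

Measured compounds:
compound 1, `CCN(CC)C(=O)c1ccccc1OCC1=NCCN1`, in a functional assay for activation of Alpha-1A adrenergic receptor (Homo sapiens), read by calcium flux (on this read-out higher numbers stand for an effect only at larger amounts of compound and lower numbers for an effect already at smaller amounts), gives < 5020 nM, a limit of the assay.
compound 2, `c1ccc(-c2ccncc2)c(OCC2=NCCN2)c1`, in this assay gives < 100000 nM, a limit of the assay.
compound 3, `Cc1cccc(-c2ccccc2OCC2=NCCN2)n1`, in this assay gives 126 nM.

Compound 2 stands only as a limit, (the limit of < 100000 nM in this assay, at which 1 of the 3 values shown sits), so its true value is not known; compound 1 is likewise only a limit, (the limit of < 5020 nM in this assay, at which 1 of the 3 values shown sits). Compound 4, `c1ccc(-c2cnccn2)c(OCC2=NCCN2)c1`, is not yet measured. The change from compound 2 is pyrazin-2-yl in place of pyridin-4-yl on an aromatic carbon. For the measured compounds named here, no measured step covers this change. Going by the values given here, compound 3, with a different six-membered aromatic ring with a hetero atom at the same place, is the only numbered value in the set. For compound 4 the expectation in this assay is 2500 nM, within 150 nM to 40000 nM; the expected step that the limit leaves unreadable from compound 2 to compound 4 cannot be sized against a limit.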

Compound 4, half-maximal effective concentration: 2.51 nM
Beside the measured number, compound 4's estimate is 1000-fold (3.00 log units) above it, and the stated range ends above it.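

The step from compound 2 to compound 4 cannot be read, because compound 2 stands only as a limit: the limit of < 100000 nM in this assay, at which 1 of the 4 values shown sits.

From the compounds shown here alone, how pyrazin-2-yl and pyridin-4-yl compare at this place stays open, as does the true value of compound 2.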